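This account rests on a few compounds, and the source may have more. Where it says the series, first, only, none or still open, it means among the compounds named here.

Going by the values given here, compound 1 `COc1ccc(-c2cn3ccnc3c(-c3ccc4ncn(C5CCCCC5)c4c3)n2)cc1` is one of three compounds measured in a functional assay on UO-31 cells (Homo sapiens) for inhibition, read by sulforhodamine B assay, with a stated time of 48 h, tested at 10 uM (a lower number here means less inhibition, a higher number more inhibition at the concentration tested (going by the name of the read-out)), where compound 1 gives 61.5%. It stands second of the three. Compound 2 `O=Cc1ccc(-c2cn3ccnc3c(-c3ccc4ncn(C5CCCCC5)c4c3)n2)cc1` gives 82.2%, and the step of a number 20.7 percentage points higher from compound 1 to compound 2 (beyond the scatter) is the change of formyl in place of methoxy on an aromatic carbon. Compound 3 `COc1ccccc1-c1cn2ccnc2c(-c2ccc3ncn(C4CCCCC4)c3c2)n1` gives 24%, and the step of a number 37.5 percentage points lower from compound 1 to compound 3 (beyond the scatter) is the change of 2-methoxyphenyl in place of 4-methoxyphenyl on an aromatic carbon.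

The unmeasured compound 4 `Fc1ccccc1-c1cn2ccnc2c(-c2ccc3ncn(C4CCCCC4)c3c2)n1` differs from compound 1 as follows: 2-fluorophenyl in place of 4-methoxyphenyl on an aromatic carbon. Among the compounds with values here, the step that bears most on this change is the one from compound 1 to compound 3, where the substituent on the phenyl ring also moved from the 4-position to the 2-position and the number fell by a large amount, a number 37.5 percentage points lower from compound 1 to compound 3 (beyond the scatter). Compound 4 repeats that relocation with fluorine in place of methoxy; because of a number 37.5 percentage points lower from compound 1 to compound 3 (beyond the scatter) a fall beyond the scatter is expected, and the estimated step is a number 31.5 percentage points lower from compound 1 to compound 4 (beyond the scatter). Compound 4 is therefore expected to give about 30%, within a range from 10% to 55%.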

Compound 4, a percentage reported as inhibition, at one concentration (the size of the read-out at that concentration, not a potency): 22.9%
Beside the measured number, compound 4's estimate is 7.1 percentage points above it; the measured number falls inside the stated range.
By their numbers in this assay, from the lowest: compounds 4 and 3 (each within the scatter of the next); then compound 1; then compound 2.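

In this assay, the change of 2-methoxyphenyl to 2-fluorophenyl makes no difference that can be told apart (a number 1.1 percentage points lower from compound 3 to compound 4 (within the scatter)), so the low number is not tied to methoxy and is shared by two quite different groups. The 2-fluorophenyl group sits as far down from the 4-substituted groups as 2-methoxyphenyl does, with large falls (a number 38.6 percentage points lower from compound 1 to compound 4 (beyond the scatter)) and (a number 59.3 percentage points lower from compound 2 to compound 4 (beyond the scatter)). Among these four compounds, both 2-substituted phenyl groups give low numbers and both 4-substituted ones give higher numbers, and no compound goes against this.

Nothing measured here gives a reason for this pattern. It also remains open whether the pattern would hold for an amine or a carboxylic acid on the phenyl ring, since only methoxy, formyl and fluoro are shown.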